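Hydroxypropyl sulfonamide extension across two cores

This account rests on a few compounds, and the source may have more. Where it says the series, first, only, none or still open, it means among the compounds named here.

Compound 1 `CC[C@@H]1C(=O)N(C)c2cnc(Nc3ccc(S(=O)(=O)NCCCO)cc3)nc2N1C1CCCC1` and compound 2 `CC[C@@H]1C(=O)N(C)c2cnc(Nc3ccc(S(N)(=O)=O)cc3)nc2N1C1CCCC1` share one core. In a functional assay on A549 cells (Homo sapiens) for antiproliferative activity, read by CCK-8 assay, with a stated time of 72 h (on this read-out lower numbers stand for stronger inhibition of growth and higher numbers for weaker inhibition of growth), compound 1 gives 437 nM, and compound 2 gives 3390 nM. For the measured compounds named here, the step of a 7.8-fold lower number from compound 2 to compound 1 (0.89 log units; beyond the scatter) is the only measured instance of this change, (3-hydroxypropyl in place of hydrogen on a sulfonamide nitrogen), in the set.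

Compound 3 `CCC1C(=O)N(C)c2cnc(Nc3ccc(S(N)(=O)=O)cc3)nc2N1c1ccn(C)n1` carries a different core; how the two cores differ is not broken down here. In this assay compound 3 is reported as "not active" (no number reported), with no number given.

Compound 4 `CCC1C(=O)N(C)c2cnc(Nc3ccc(S(=O)(=O)NCCCO)cc3)nc2N1c1ccn(C)n1` applies to compound 3 the same change, (3-hydroxypropyl in place of hydrogen on a sulfonamide nitrogen), at the same place, so the two changes are the same change on two cores. Going by the values given here, the expectation for compound 4 rests on the one measured step of a 7.8-fold lower number from compound 2 to compound 1 (0.89 log units; beyond the scatter), but it starts from compound 3, which has no number, so the starting point is itself uncertain. Compound 4 is therefore expected to stay weak in this assay, with an estimate of 6000 nM and a wide range from 1200 nM to 40000 nM, and a real chance that only a limit is reported.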

Compound 4, concentration for 50% growth inhibition: 48900 nM
Compound 4: the middle estimate sits 8.2-fold (0.91 log units) below what was measured; measured number above the stated range.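

For the compounds shown here, compound 3 carries no number in this assay, while compound 4 gives 48900 nM, so no step from compound 3 to compound 4 can be read. The compounds shown leave open whether adding 3-hydroxypropyl on the sulfonamide nitrogen shifts the read-out on the core of compound 3 as it does on the core of compound 1. No supporting evidence bears on this result.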